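A Fluorine-for-Methoxy Exchange on the Ring Nitrogen Aryl

This account rests on a few compounds, and the source may have more. Where it says the series, first, only, none or still open, it means among the compounds named here.

Compound 1 `COc1ccc(OC)c(N2C(=O)CSC2c2cccc(C(=O)NCCCCc3ccccc3)c2)c1` carries a 2,5-dimethoxyphenyl group on the amide-type nitrogen of its core. In a functional assay on HOS-TE85 cells (Homo sapiens) for inhibition, read by CCK-8 assay, with a stated time of 72 h (on this read-out higher numbers stand for weaker inhibition and lower numbers for stronger inhibition), compound 1 gives > 1000 nM, which is a limit of the assay rather than a number, so compound 1 stands only at the weak end of what has been measured. The other two compounds give numbers. Compound 2 `CCOC(=O)c1sc(N2C(=O)CSC2c2cccc(C(=O)NCCCCn3cccn3)c2)nc1C` gives 430 nM in this assay, and compound 3 `O=C(NCCCCn1cccn1)c1cccc(C2SCC(=O)N2c2cc(Cl)ccn2)c1` gives 36.4 nM. Within the data shown here, the one measured step, a 12-fold lower number from compound 2 to compound 3 (1.07 log units; beyond the scatter), sits at that same ring nitrogen and shows that what stands there can move the read-out substantially.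

Compound 4 `COc1c(F)cccc1N1C(=O)CSC1c1cccc(C(=O)NCCCCc2ccccc2)c1` is not yet measured; it differs from compound 1 by 3-fluoro-2-methoxyphenyl in place of 2,5-dimethoxyphenyl on an amide-type nitrogen in a ring. Among the measured compounds shown here, no measured pair shows this particular exchange; the step of a 12-fold lower number from compound 2 to compound 3 (1.07 log units; beyond the scatter) concerns different groups at that nitrogen and only shows that the position matters. Because compound 1 gives (the limit of > 1000 nM in this assay, at which 1 of the 3 values shown sits), the starting point is itself uncertain. Compound 4 is therefore expected to give roughly 1000 nM in this assay, with a range from 300 nM to 3000 nM. The step of a number no higher from compound 1 to compound 4 (the limit leaves the size open) is expected to be modest, and compound 4 may well return only a limit again.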

Compound 4, half-maximal inhibitory concentration: 26.2 nM
The estimate for compound 4 lay 38-fold (1.58 log units) above the measured number, outside the stated range (below it).
By their numbers in this assay, from the lowest: compounds 4 and 3 (each within the scatter of the next); then compound 2. At a limit, above all of these: compound 1.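

In this assay, exchanging 2,5-dimethoxyphenyl for 3-fluoro-2-methoxyphenyl on the amide-type nitrogen in the ring, with the rest of the molecule unchanged, gives an at least 38-fold lower number from compound 1 to compound 4 (1.58 log units; beyond the scatter). The earlier step at this nitrogen replaced one kind of ring with another, whereas here the six-membered aromatic ring of carbon only stays and just the groups it carries change, and that alone is enough to move a compound from a limit of the assay to a measured number. The full size of the step remains unknown because compound 1 stands at a limit of the assay rather than at a number: the limit of > 1000 nM in this assay, at which 1 of the 4 values shown sits.

The exchange removes one methoxy group, shifts the other and adds a fluorine all at once, so the compounds shown cannot tell which of these changes accounts for the lower number, and no measured property explains it. They also leave open how a chlorine, a hydroxyl group or an amine in the place of that fluorine would read in this assay.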